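The source may hold more compounds than are shown below. What is called first, only, known or untested is meant among the compounds shown, and "the series" means these compounds.

Measured so far in a functional assay on MGC-803 cells (Homo sapiens) for antiproliferative activity, read by CCK-8 assay, with a stated time of 72 h, tested at 2 uM; a higher number here means a stronger effect of the compound at the concentration tested, a lower number a weaker effect:
compound 1 `Nc1ccccc1NC(=O)c1ccc(CSC(=S)N2CCCc3ccccc32)cc1` gives 38.5%;
compound 2 `CN1CCN(C(=S)SCc2ccc(C(=O)Nc3ccccc3N)cc2)CC1` gives 29.6%.

Compound 2 holds the lower of the two numbers, yet it lies within the scatter of compound 1, so no order between them is read. Compound 3 `CN(Cc1ccncc1)C(=S)SCc1ccc(C(=O)Nc2ccccc2N)cc1` carries the change (methyl((pyridin-4-yl)methyl)amino in place of 4-methylpiperazin-1-yl on a thiocarbonyl carbon). Going by the values given here, the one measured step that bears on it, a number 8.9 percentage points lower from compound 1 to compound 2 (within the scatter), also exchanged the group on a thiocarbonyl carbon and stayed within the scatter. Compound 3 is therefore expected to stay close to compound 2, with an estimated step of a number 0.4 percentage points higher from compound 2 to compound 3 (within the scatter). The estimate for compound 3 is 30%, with a range from 15% to 45%.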

Compound 3, a percentage reported as inhibition, at one concentration (the size of the read-out at that concentration, not a potency): 38.1%
Compound 3: the middle estimate sits 8.1 percentage points below what was measured; the range from low to high includes it.
By their numbers in this assay, from the lowest: compounds 2, 3 and 1 (each within the scatter of the next).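

Going by these compounds alone, with methyl((pyridin-4-yl)methyl)amino on the thiocarbonyl carbon, the nitrogen lies outside a ring for the first time, and this assay gives a number 8.5 percentage points higher from compound 2 to compound 3 (within the scatter) and a number 0.4 percentage points lower from compound 1 to compound 3 (within the scatter). The three groups, with or without an aromatic ring, therefore lie within the scatter of one another, and no preference among them can be read. No evidence on hand explains these numbers.

On these data alone, whether a morpholin-4-yl group, a dimethylamino group or a longer chain on the nitrogen would move the number beyond the scatter stays open. Also open, as far as these compounds go, is whether the pyridin-4-yl ring itself matters, which a phenyl ring in its place would test.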